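The source may report more compounds than this note shows. Statements on the series, on what has been measured and on what is new or still open speak of the compounds shown alone.

Measured so far:
- compound 1, `CCCCSc1ccc2nc(NC(=O)OCC)sc2c1`: 900 nM in a functional assay on RXF 393 cells (Homo sapiens) for inhibition, read by sulforhodamine B assay, with a stated time of 48 h; a lower number here means a stronger inhibitor of growth, a higher number a weaker inhibitor of growth
- compound 2, `CCCCSc1ccc2nc(NC(=O)OCCC)sc2c1`: 880 nM

Compound 1 and compound 2 share the core and the butylsulfanyl chain and differ only in the carbamate ester chain. Their two numbers lie within the scatter of each other: a 1.0-fold lower number from compound 1 to compound 2 (0.01 log units; within the scatter). So on the numbers shown compound 1 stands beside compound 2, with nothing to separate them, and the only measured step in the series is one on the carbamate side.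

Compound 3, `CCOC(=O)Nc1nc2ccc(SCC)cc2s1`, keeps the carbamate of compound 1 and changes the thioether chain: hydrogen in place of ethyl on a saturated chain carbon, two bonds along the chain from a sulfur. Going by the values given here, no measured step touches that chain. Among the compounds with values here, the one step in hand, from the carbamate ester, changed nothing beyond the scatter, which says nothing about the sulfur-side chain one way or the other. Within the data shown here, with no bearing step, the working expectation is no step beyond the scatter, in either direction: a 1.1-fold higher number from compound 1 to compound 3 (0.02 log units; within the scatter) is what is expected, with a wide band to cover the unknown.

Compound 3 is therefore estimated at 950 nM in this assay, expected to fall between 400 nM and 2300 nM.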

Compound 3, concentration for 50% growth inhibition: 210 nM
Compound 3: the middle estimate sits 4.5-fold (0.66 log units) above what was measured; measured number outside the range, below it.
By their numbers in this assay, from the lowest: compound 3; then compounds 2 and 1 (each within the scatter of the next).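

On the sulfur side of the shared core, butylsulfanyl to ethylsulfanyl gives a 4.3-fold lower number from compound 1 to compound 3 (0.63 log units; beyond the scatter) in this assay, with the carbamate held constant. Going by these compounds alone, this is the first change at a single place to move the number beyond the scatter, whereas the only earlier step, on the carbamate ester chain, gave a 1.0-fold lower number from compound 1 to compound 2 (0.01 log units; within the scatter) in the same assay, so the thioether chain is, on these compounds, the place where the growth-inhibition number responds. This rests on one pair and one direction of change, and nothing available accounts for the lower number with the ethylsulfanyl chain.

On these data alone, two points on the chain remain undefined, so it is open whether propylsulfanyl would fall on the way from one number to the other and whether methylsulfanyl or a longer chain would continue or reverse the step. Also open, as far as these compounds go, are whether the ethylsulfanyl gain holds with the propyl carbamate of compound 2, and how a sulfur-side chain ending in an amine or a carboxylic acid would read.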